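Changing One Group on a Sulfonyl Sulfur

A few compounds are considered here, and "the series" means these few. Any claim that something is new, unique, unknown or untested is made for them only; others in the source may bear on it.

Of the compounds shown here, two have been tested so far, and neither gives an exact potency. In a functional assay on A2780 cells (Homo sapiens) for antiproliferative activity, read by sulforhodamine B assay, with a stated time of 72 h (on this read-out higher numbers stand for weaker inhibition and lower numbers for stronger inhibition), compound 1 `O=C(NCc1cnccn1)Nc1ccc(S(=O)(=O)c2ccccc2)cc1` gives > 2000 nM, which is a limit of the assay and not a number. In this assay, compound 2 `O=C(NCc1cccnc1)Nc1ccc(S(=O)(=O)N2CC3(COC3)C2)cc1` gives > 2000 nM, which is also a limit. Together they make up the whole evidence so far: the limit of > 2000 nM in this assay, at which 2 of the 2 values shown sit. Compound 2 therefore offers a limit, not a precise starting point.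

Compound 3 `O=C(NCc1cccnc1)Nc1ccc(S(=O)(=O)N[C@H]2CC[C@H](O)CC2)cc1` differs from compound 2 in one place, on a sulfonyl sulfur: a group of 8 heavy atoms (6 carbon, 1 nitrogen, 1 oxygen; one six-membered non-aromatic ring of carbon only) in place of a group of 7 heavy atoms (5 carbon, 1 nitrogen, 1 oxygen; 2 four-membered non-aromatic rings with 1 hetero atom each), on a sulfonyl sulfur. A (4-hydroxycyclohexyl)amino group enters there, bringing one six-membered non-aromatic ring of carbon only in place of 2 four-membered non-aromatic rings. Among the compounds with values here, no measured step between similar compounds is available to show what such a change does.

The estimated step of an at least 1.3-fold lower number from compound 2 to compound 3 (0.12 log units; that floor lies within the scatter) is small and points, if at all, towards slightly stronger inhibition. Another limit would be no surprise. In this assay, the expected value for compound 3 is 1500 nM, with an estimated range of 200 nM to 5000 nM.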

Compound 3, half-maximal inhibitory concentration: 369 nM
Estimate against measurement, compound 3: 4.1-fold (0.61 log units) above; measured number inside the range.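

In this assay, replacing the group with two four-membered rings by (4-hydroxycyclohexyl)amino on the sulfonyl sulfur gives an at least 5.4-fold lower number from compound 2 to compound 3 (0.73 log units; beyond the scatter), so a change at this one position can move the read-out by more than the usual scatter. Within the data shown here, compound 3 also supplies the first exact value, 369 nM, and with it a measured starting point for later comparisons. The size of the step remains a floor, and most of the series still offers no exact number to compare with: the limit of > 2000 nM in this assay, at which 2 of the 3 values shown sit.

This single step changes several things at once, including the ring, the count of hydrogen-bond donors and the presence of defined stereocentres, so the compounds shown cannot say which of these differences goes with the lower number. A plain cyclohexylamino group without the hydroxyl, or a 4-aminocyclohexyl group carrying an amine in its place, would be needed to separate the role of the hydroxyl from that of the six-membered carbon ring, and the other stereoisomer would show whether the arrangement of the ring matters.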